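Removing one chloro from the shared core of compound 1

A few compounds are considered here, and "the series" means these few. Any claim that something is new, unique, unknown or untested is made for them only; others in the source may bear on it.

Measured so far in a functional assay on SK-MEL-2 cells (Homo sapiens) for cytotoxicity, read by sulforhodamine B assay, with a stated time of 48 h; on this read-out higher numbers stand for lower toxicity in this test and lower numbers for higher toxicity in this test:
- compound 1, `ClCc1ccc(Cn2cnc3nc(Cl)nc(Cl)c32)cc1`, gives 6450 nM.
- compound 2, `ClCc1ccccc1Cn1cnc2ncnc(Cl)c21`, gives only a limit of the assay, > 100000 nM.
- compound 3, `ClCc1ccccc1Cn1cnc2nc(Cl)nc(Cl)c21`, gives only a limit of the assay, > 100000 nM.

Compound 1 is the only one of the three with a number in this assay. The difference between the core of compound 1 and that of compound 3 is not broken down here. Between compound 3 and compound 2 the change is hydrogen in place of chloro on an aromatic carbon; the step that the two limits leave unreadable from compound 3 to compound 2 has no readable size because both values sit at the limit of > 100000 nM in this assay, at which 2 of the 3 values shown sit.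

Compound 4, `ClCc1ccc(Cn2cnc3ncnc(Cl)c32)cc1`, has not yet been measured. It differs from compound 1 by hydrogen in place of chloro on an aromatic carbon, the same change as that from compound 3 to compound 2, since the place is described in the same words for both. The earlier step gives no measured size to lean on, so the expectation for compound 4 rests on compound 1 alone and is wide: the step is estimated at a 3.1-fold higher number from compound 1 to compound 4 (0.49 log units; beyond the scatter). Compound 4 is expected to give about 20000 nM, between 4000 nM and 100000 nM.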

Compound 4, concentration lethal to 50% of the cells: > 100000 nM
Compound 4: no number, only a limit; the forecaster's own chance of this, stated with the estimate: 40%; middle value at least 5.0-fold (0.69 log units) away from the limit.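

In this assay, hydrogen in place of chloro on an aromatic carbon, between two ring nitrogen atoms, gives an at least 15-fold higher number from compound 1 to compound 4 (1.19 log units; beyond the scatter), so on this core the loss of that chloro goes with a large drop in toxicity in this test. Compound 4 gives only a limit of the assay, > 100000 nM, so the printed size of the step is a bound and not a measured size. Whether the step carries over to the core of compound 3 is not shown, because the step from compound 3 to compound 2 cannot be read: the limit of > 100000 nM in this assay, at which 3 of the 4 values shown sit.

Left open is whether an amine, a methoxy group or a thiol in that same place would keep a number in this assay, since the compounds shown hold only chloro or hydrogen there. Also open, on these data alone, is what would follow if an amine took the place of the remaining chloro group, which compound 4 and compound 2 both keep.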